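The compounds below may be only part of what the source reports. "The series", "measured", "known", "first", "only" and "open" are said of these compounds alone.

Of the compounds shown here, two have numbers so far. Compound 2 `O=C(NC1CC1)C1CCN(c2cncnc2-c2ccccc2)CC1` gives 44 nM in an assay on HEK293F cells for inhibition of cholesterol 24-hydroxylase (Homo sapiens), read by trypan blue exclusion, with stated times of 15 min and 5 h; on this read-out higher numbers stand for weaker inhibition and lower numbers for stronger inhibition. Compound 1 `O=C(NC1CC1)C1CCN(c2cnccc2-c2ccccn2)CC1` differs from compound 2 in more than one place. In this assay compound 1 gives 160 nM; of the two numbers, that of compound 2 is the lower, and the gap to compound 1 is beyond the scatter. Within the data shown here, no single-change step between measured compounds is available to guide the next move.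

Compound 3 `O=C(Nc1ccccc1)C1CCN(c2cncnc2-c2ccccc2)CC1` follows from compound 2 by one change: phenyl in place of cyclopropyl on an amide-type nitrogen. Among the measured compounds shown here, with no comparable step on record, the expectation is a small shift in this assay, if any, likely not beyond the scatter, with the wider spread of outcomes leaning towards a somewhat higher number. Compound 3 is therefore expected to give about 70 nM in this assay, within 18 nM to 280 nM, which means an estimated step of a 1.6-fold higher number from compound 2 to compound 3 (0.20 log units; within the scatter).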

Compound 3, half-maximal inhibitory concentration: 28 nM
Beside the measured number, compound 3's estimate is 2.5-fold (0.40 log units) above it; the range from low to high includes it.
By their numbers in this assay, from the lowest: compounds 3 and 2 (each within the scatter of the next); then compound 1.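

In this assay, phenyl in place of cyclopropyl on the amide-type nitrogen amounts to a 1.6-fold lower number from compound 2 to compound 3 (0.20 log units; within the scatter), the first single-change step available in the series. At this position, the read-out therefore does not separate a three-membered non-aromatic ring of 3 heavy atoms from a six-membered aromatic ring of 6 heavy atoms, so the amide nitrogen can carry either group without a shift beyond the scatter. No supporting measurement is available to explain this outcome.

Still open, on these data alone, is how this nitrogen responds to a benzyl group, a longer alkyl chain, or a phenyl ring carrying an amine or a carboxylic acid. Also open, as far as these compounds go, is how the difference in number between compound 1 and the other two compounds divides among the several places in which its structure differs.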